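Bromo to fluoro exchange in the cytotoxicity series

A few compounds are considered here, and "the series" means these few. Any claim that something is new, unique, unknown or untested is made for them only; others in the source may bear on it.

Measured so far:
compound 1 `O=C1COc2ccc(-c3[nH]c(-c4ccc(C(F)(F)F)cc4)nc3-c3ccccc3)cc2N1`, 21.7%
compound 2 `O=C1COc2ccc(-c3nn(-c4ccc(Br)cc4)cc3-c3ccccc3)cc2N1`, 58.8%

In a functional assay on A549 cells (Homo sapiens) for cytotoxicity, read by colorimetric assay and MTT assay, with a stated time of 3 days, tested at 20 uM (a higher number here means a weaker effect of the compound at the concentration tested, a lower number a stronger effect), compound 2 gives 58.8%, the higher of the two numbers; compound 1 gives 21.7%, a gap that lies beyond the scatter. Compound 3 `O=C1COc2ccc(-c3nn(-c4ccc(F)cc4)cc3-c3ccccc3)cc2N1` differs from compound 2 by fluoro in place of bromo on an aromatic carbon. For the measured compounds named here, no step between measured compounds is available to guide the size of this change. A small step in this assay, if any, is expected, probably not beyond the scatter. Compound 3 is expected at 62%, within 45% to 79%. This means an expected step of a number 3.2 percentage points higher from compound 2 to compound 3 (within the scatter).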

Compound 3, a percentage reported as activity, at one concentration (the size of the read-out at that concentration, not a potency): 56.4%
Estimate against measurement, compound 3: 5.6 percentage points above, and the stated range covers the measured number.
By their numbers in this assay, from the lowest: compound 1; then compounds 3 and 2 (each within the scatter of the next).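

In this assay, for the compounds shown here, the first step that changes one place reads a number 2.4 percentage points lower from compound 2 to compound 3 (within the scatter). At this place, on an aromatic carbon para to a large group, the exchange of 4-bromophenyl for 4-fluorophenyl therefore gives no read-out difference beyond the scatter. No supporting data bear on this result.

Still open, as far as these compounds go, is whether an amine or a carboxylic acid at this place would shift the read-out beyond the scatter. The compounds shown also leave open whether the shared core would tolerate such a group equally well.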